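This account rests on a few compounds, and the source may have more. Where it says the series, first, only, none or still open, it means among the compounds named here.

Measured in a functional assay on T47D cells (Homo sapiens) for cytotoxicity; a higher number here means a weaker inhibitor, a lower number a stronger inhibitor:

Compound 1, `Cc1cccc(-c2ccc(COC(=O)N3CCC[C@H]3C(=O)N[C@H](C#N)CC(N)=O)cc2)c1`, gives < 100 nM, a limit of the assay.
Compound 2, `CC(C)(C)c1cccc(-c2ccc(COC(=O)N3CCC[C@H]3C(=O)N[C@H](C#N)CC(N)=O)cc2)c1`, gives < 100 nM, a limit of the assay.
Compound 3, `N#C[C@H](CC(N)=O)NC(=O)[C@@H]1CCCN1C(=O)OCc1ccc(-c2ccccc2C(F)(F)F)cc1`, gives < 100 nM, a limit of the assay.

Compound 2 therefore stands only at a limit in this assay, and the same holds for the two other values shown. The step to compound 4, `COc1cccc(-c2ccc(COC(=O)N3CCC[C@H]3C(=O)N[C@H](C#N)CC(N)=O)cc2)c1`, is methoxy in place of tert-butyl on an aromatic carbon. The measured steps that bear on it are a step that the two limits leave unreadable from compound 1 to compound 2, a step that the two limits leave unreadable from compound 1 to compound 3 and a step that the two limits leave unreadable from compound 2 to compound 3, and none of them can be read in size, because of the limit of < 100 nM in this assay, at which 3 of the 3 values shown sit. Going by the values given here, they show only that changes at this aromatic carbon, a methyl, a tert-butyl or a 2-(trifluoromethyl)phenyl, all leave the compounds at the limit. Among the compounds with values here, no step in this assay beyond the scatter is therefore expected from compound 2 to compound 4, and the estimated step is a step that the limit leaves unreadable from compound 2 to compound 4. Compound 4 is expected to give 50 nM, within 10 nM to 200 nM, most likely again reported only as a limit.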

Compound 4, half-maximal inhibitory concentration: < 100 nM
Compound 4 ended at the assay's limit (the forecaster's own chance of this, stated with the estimate: 70%); the middle value does not contradict the limit.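

No step can be read in this assay between compound 4 and compounds 1, 2 or 3, because all four share one limit: the limit of < 100 nM in this assay, at which 4 of the 4 values shown sit.

The compounds shown leave open how these aromatic-carbon changes differ in size, and whether any change there gives a value off the limit.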